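A few compounds are considered here, and "the series" means these few. Any claim that something is new, unique, unknown or untested is made for them only; others in the source may bear on it.

Measured compounds:
- compound 1 `O=C(NCc1ccc(F)cc1)c1nc(Br)c2cccnc2c1NCCCNc1c(C(=O)NCc2ccc(F)cc2)nc(Br)c2cccnc12` in a functional assay on HCT-116 cells (Homo sapiens) for cytotoxicity, read by MTT assay, with a stated time of 72 h; on this read-out lower numbers stand for stronger inhibition and higher numbers for weaker inhibition: > 20000 nM
- compound 2 `C[C@@H](CO)Nc1nc(C(=O)NCc2ccc(F)cc2)c(O)c2ncccc12`: "not determined" (no result reported)
- compound 3 `CS(=O)(=O)Oc1c(C(=O)NCc2ccc(F)cc2)nc(Br)c2cccnc12`: > 20000 nM

Compound 3 gives > 20000 nM in this assay, which is a limit of the assay and not a number. Compound 1 also reaches only > 20000 nM in this assay, again a limit. Compound 2 has no result in this assay. Among the compounds with values here, compound 3 therefore stands nowhere on a scale of numbers: two of the three entries sit at the limit of > 20000 nM in this assay, at which 2 of the 3 values shown sit, and the third carries no value, so no step between measured compounds can be drawn.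

Compound 4 `C[C@@H](Nc1c(C(=O)NCc2ccc(F)cc2)nc(Br)c2cccnc12)c1ccccc1` differs from compound 3 in one place: (1-phenylethyl)amino in place of (methylsulfonyl)oxy on an aromatic carbon. The change sits on an aromatic carbon of a six-membered aromatic ring with one nitrogen, para to the bromo group of the shared core.

Within the data shown here, with no measured step to lean on, the direction of the change is open. The expectation for compound 4 is an entry below the limit rather than another limit, so a step from compound 3 of an at least 2.5-fold lower number from compound 3 to compound 4 (0.39 log units; beyond the scatter) in the direction of stronger inhibition is expected, beyond the usual scatter but with wide uncertainty. Compound 4 is estimated at 8000 nM, within a range from 800 nM to 20000 nM.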

Compound 4, half-maximal inhibitory concentration: > 20000 nM
Compound 4: only a limit was reported (the forecaster's own chance of this, stated with the estimate: 45%); middle value at least 2.5-fold (0.39 log units) away from the limit.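

In this assay compound 3 and compound 4 both stand at a limit of the assay and not at a number, so no step can be read between them: the limit of > 20000 nM in this assay, at which 3 of the 4 values shown sit.

The compounds shown leave open whether any group at this place on the shared core gives a number rather than a limit.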